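Swapping a pyrazole for a trimethoxyphenyl on the shared core

The compounds below may be only part of what the source reports. "The series", "measured", "known", "first", "only" and "open" are said of these compounds alone.

Of the compounds shown here, three have been tested in a functional assay on HCC78 cells (Homo sapiens) for antiproliferative activity, read by MTT assay, with a stated time of 48 h; on this read-out higher numbers stand for weaker inhibition and lower numbers for stronger inhibition. Compound 1 `Cc1cnc(Nc2ncccc2OC(C)c2cccc(C(=O)NCc3ccc(F)c(Cl)c3)c2)s1` gives 34700 nM, compound 2 `COc1cccc(CNC(=O)c2cccc(C(C)Oc3ccnc(Nc4cnn(C)c4)c3)c2)c1` gives 64400 nM, and compound 3 `Cc1ccc(CNC(=O)c2cccc(C(C)Oc3ccnc(Nc4cn(C)nc4C)c3)c2)cc1` gives 17500 nM. Compound 3 thus has the smallest number of the three, though the gap to compound 1 lies within the usual scatter of repeated measurements, so those two cannot be told apart; only compound 2 stands clearly beyond that scatter from compound 3. All three numbers sit in a range where inhibition of cell growth is weak.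

Compound 4 `COc1cc(Nc2cc(OC(C)c3cccc(C(=O)NCc4ccc(C)cc4)c3)ccn2)cc(OC)c1OC` has not yet been measured. It differs from compound 3 in one place: 3,4,5-trimethoxyphenyl in place of 1,3-dimethyl-1H-pyrazol-4-yl on a nitrogen on an aromatic ring. For the measured compounds named here, no pair of measured compounds differing only in this way exists, so there is no measured step to lean on. The change is expected to move the number in this assay only modestly, if at all, since the three measured values are all weak and close. Compound 4 is estimated at 12000 nM, with a range from 3000 nM to 50000 nM, which means an expected step of a 1.5-fold lower number from compound 3 to compound 4 (0.16 log units; within the scatter).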

Compound 4, half-maximal inhibitory concentration: 15700 nM
Compound 4: middle estimate off by 1.3-fold (0.12 log units), on the low side; low and high end bracket the measured number.
By their numbers in this assay, from the lowest: compounds 4, 3, 1 and 2 (each within the scatter of the next, the first and the last beyond it).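

In this assay the swap of 1,3-dimethyl-1H-pyrazol-4-yl for 3,4,5-trimethoxyphenyl on a nitrogen on an aromatic ring gives a 1.1-fold lower number from compound 3 to compound 4 (0.05 log units; within the scatter) and so leaves compound 3 and compound 4 indistinguishable. This first measured step at this position shows that a six-membered aromatic ring of carbon only, with 12 heavy atoms in place of 7, can stand here without a clear gain or loss in this read-out. Nothing available explains this flat result.

As far as these compounds go, whether any group at this position can move the number clearly remains open, as only these two have been compared directly. A plain phenyl, or a phenyl carrying an amine or a carboxylic acid in place of the methoxy groups, would test this further.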